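Chloro on compound 1: expected stability of compound 3

The source may report more compounds than this note shows. Statements on the series, on what has been measured and on what is new or still open speak of the compounds shown alone.

Among the measured compounds shown here, in an ADME assay on microsomes from liver (Mus musculus) for metabolic stability, read by LC-MS, using NADPH, with a stated time of 10 min, tested at 0.5 uM (a higher number here means that more of the compound is left, a lower number that less of the compound is left), compound 1 (`COC(=O)Nc1cc(-c2ccc(OC[C@@](C)(N)CC(C)C)cn2)ccn1`) gives 93% and stands highest of the two numbers so far. Compound 2 (`COC(=O)Nc1cc(-c2ccc(OC[C@@](C)(N)CC(C)C)c(F)c2)ccn1`) gives 71%, and the gap between these two numbers lies beyond the scatter. Compound 3 (`COC(=O)Nc1cc(-c2ccc(OC[C@@](C)(N)CC(C)C)c(Cl)n2)ccn1`) differs from compound 1 by chloro in place of hydrogen on an aromatic carbon and so has chloro in place of hydrogen on an aromatic carbon, next to the ring nitrogen and ortho to a (2-amino-2,4-dimethylpentyl)oxy group. For the measured compounds named here, no measured one-place step is available. A slight downward move within the scatter is expected in this assay with a number 8 percentage points lower from compound 1 to compound 3 (within the scatter) as the estimated step. Compound 3 is estimated at 85% with an expected range from 66% to 97% for this reading.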

Compound 3, percent of the compound remaining: 72%
Compound 3: middle estimate off by 13 percentage points, on the high side; the range from low to high includes it.
By their numbers in this assay, from the lowest: compounds 2 and 3 (each within the scatter of the next); then compound 1.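

In this assay, chloro in place of hydrogen on this aromatic carbon, next to the ring nitrogen and ortho to a (2-amino-2,4-dimethylpentyl)oxy group, gives a number 21 percentage points lower from compound 1 to compound 3 (beyond the scatter). This first one-place step in the series shows that the position is sensitive to substitution: one chlorine atom moves the reading beyond the scatter. Nothing available bears on the cause of this step. On these data alone, whether a methyl, methoxy or nitrile on the same carbon gives a step of similar size remains open. Also open, as far as these compounds go, is whether chloro at another position on this ring gives the same result.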